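The source may report more compounds than this note shows. Statements on the series, on what has been measured and on what is new or still open speak of the compounds shown alone.

Measured so far:
compound 1, `ClCc1ccccc1Cn1cnc2c(Cl)nc(Cl)nc21`: 370 nM
compound 2, `ClCc1ccccc1Cn1cnc2c(Cl)ncnc21`: 5120 nM
compound 3, `ClCc1cccc(Cn2cnc3ncnc(Cl)c32)c1`: 47900 nM

In a functional assay on K562 cells (Homo sapiens) for cytotoxicity, read by sulforhodamine B assay, with a stated time of 48 h (on this read-out lower numbers stand for stronger inhibition of growth and higher numbers for weaker inhibition of growth), compound 1 gives 370 nM, compound 2 gives 5120 nM and compound 3 gives 47900 nM. Compound 2 and compound 1 differ in one place, (chloro in place of hydrogen on an aromatic carbon), and this change made a 14-fold lower number from compound 2 to compound 1 (1.14 log units; beyond the scatter). Compound 3 has the same atoms as compound 2 joined differently; the difference between the two cores is not broken down here. Compound 4, `ClCc1cccc(Cn2cnc3nc(Cl)nc(Cl)c32)c1`, is not yet measured and differs from compound 3 by chloro in place of hydrogen on an aromatic carbon, the same change as that from compound 2 to compound 1, with the place described in identical terms; the change appears in two pairs among these compounds. Because of a 14-fold lower number from compound 2 to compound 1 (1.14 log units; beyond the scatter) a step of similar size is expected, a 14-fold lower number from compound 3 to compound 4 (1.14 log units; beyond the scatter), though it rests on a single precedent. Compound 4 is estimated at 3500 nM, expected between 1200 nM and 10000 nM.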

Compound 4, concentration for total growth inhibition: 2690 nM
For compound 4 the middle estimate is 1.3-fold (0.11 log units) above the measured one; low and high end bracket the measured number.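

In this assay chloro in place of hydrogen on an aromatic carbon gives an 18-fold lower number from compound 3 to compound 4 (1.25 log units; beyond the scatter) on the core of compound 3. The step therefore carries from one core to the other in this series with its size kept: the same change on two cores in this assay, a 14-fold lower number (1.14 log units; beyond the scatter) from compound 2 to compound 1 and an 18-fold lower number (1.25 log units; beyond the scatter) from compound 3 to compound 4, 1.3-fold (0.11 log units) apart, within the scatter of two such steps. This rests on two pairs in one cell line, so it shows nothing about other cores and does not explain the change.

Open, from the compounds shown here alone, is whether an amine or a methoxy group at the same place, between two ring nitrogen atoms, would give a step of like size. Also open, going by these compounds, is whether the step holds when a hydroxymethyl group stands in place of the chloromethyl group.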